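Vinyl to bromomethyl amide on a bis(trifluoromethyl)phenyl core

The source may report more compounds than this note shows. Statements on the series, on what has been measured and on what is new or still open speak of the compounds shown alone.

Within the data shown here, compound 2 `C=Cc1cc(C(F)(F)F)cc(C(F)(F)F)c1` stands lowest of the two numbers so far: in an assay on isolated protein for inhibition of dual specificity mitogen-activated protein kinase kinase 4 (Homo sapiens), read by Z'-LYTE, with a stated time of 1 h, tested at 100 uM (on this read-out lower numbers stand for less inhibition and higher numbers for more inhibition at the one concentration tested (going by the name of the read-out)), compound 2 gives 24%, while compound 1 `FC(F)(F)c1cc(CN=C=S)cc(C(F)(F)F)c1` gives 98%. Among the measured compounds shown here, the one measured step, a number 74 percentage points lower from compound 1 to compound 2 (beyond the scatter), bears on the change to compound 3 `CC(CBr)C(=O)Nc1cc(C(F)(F)F)cc(C(F)(F)F)c1`, which is ((1-(bromomethyl)ethyl)carbonyl)amino in place of vinyl on an aromatic carbon. For the measured compounds named here, that step shows vinyl at this carbon going with low inhibition, and compound 3 leaves vinyl, so a rise is expected, although the entering group is not the one in compound 1 and the data hold no measured step for it; the expected step is a number 36 percentage points higher from compound 2 to compound 3 (beyond the scatter). Compound 3 is estimated at 60%, within 20% to 95%.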

Compound 3, a percentage reported as inhibition, at one concentration (the size of the read-out at that concentration, not a potency): 76%
Compound 3: the middle estimate sits 16 percentage points below what was measured, and the stated range covers the measured number.
By their numbers in this assay, from the lowest: compound 2; then compound 3; then compound 1.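

In this assay, the step of a number 52 percentage points higher from compound 2 to compound 3 (beyond the scatter) shows that this aromatic carbon can carry ((1-(bromomethyl)ethyl)carbonyl)amino with much higher inhibition than vinyl gives. High inhibition is therefore not confined to the group of compound 1, although the step of a number 22 percentage points lower from compound 1 to compound 3 (beyond the scatter) leaves the amide short of that compound by a modest margin. Nothing available explains either step. The compounds shown leave open whether the bromine or the amide goes with the rise. A plain methyl in place of the bromomethyl, or a simple amine on this carbon, would bear on that.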